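This account rests on a few compounds, and the source may have more. Where it says the series, first, only, none or still open, it means among the compounds named here.

The measured compounds:

Compound 1, `CCCCCCCCCCCCOC1=C(O)OC(C(O)CO)C1=O`, gives 54000 nM in a functional assay (brain) for inhibition, with Rattus norvegicus as the target; a lower number here means a stronger inhibitor, a higher number a weaker inhibitor.
Compound 2, `CCCCCCCCCCCCCOC1=C(O)OC(C(O)CO)C1=O`, gives 7400 nM in this assay.
Compound 3, `CCCCCCCCCCCCCCCOC1=C(O)OC(C(O)CO)C1=O`, gives 5600 nM in this assay.

Three compounds share a core and differ only in the length of a saturated chain. From compound 1 to compound 2 the change is methyl in place of hydrogen on a saturated chain carbon, ten or more bonds along the chain from an oxygen on an unsaturated carbon, and it brings a 7.3-fold lower number from compound 1 to compound 2 (0.86 log units; beyond the scatter). From compound 1 to compound 3 the change is propyl in place of hydrogen on a saturated chain carbon, ten or more bonds along the chain from an oxygen on an unsaturated carbon, and it brings a 9.6-fold lower number from compound 1 to compound 3 (0.98 log units; beyond the scatter). Between compound 2 and compound 3, however, the step is a 1.3-fold lower number from compound 2 to compound 3 (0.12 log units; within the scatter), so the two longer chains cannot be told apart in this assay.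

Compound 4, `CCCCCCCCCCCCCCCCOC1=C(O)OC(C(O)CO)C1=O`, has not been measured. It differs from compound 3 by methyl in place of hydrogen on a saturated chain carbon, ten or more bonds along the chain from an oxygen on an unsaturated carbon, which is the same change as that from compound 1 to compound 2, made on a chain that is already longer. The first time this change was made it gave a modest step, but the step from compound 2 to compound 3 was within the scatter, so the gain from lengthening the chain appears to have levelled off by compound 3. Compound 4 is therefore expected to show a 1.2-fold lower number from compound 3 to compound 4 (0.09 log units; within the scatter), a small step resting on the flat step a 1.3-fold lower number from compound 2 to compound 3 (0.12 log units; within the scatter) rather than on the larger one a 7.3-fold lower number from compound 1 to compound 2 (0.86 log units; beyond the scatter). Compound 4 is estimated at 4500 nM, with a range from 2000 nM to 12000 nM.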

Compound 4, half-maximal inhibitory concentration: 6800 nM
Beside the measured number, compound 4's estimate is 1.5-fold (0.18 log units) below it, and the stated range covers the measured number.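

Carried onto the longer chains in this assay, the methyl change gives a 1.2-fold higher number from compound 3 to compound 4 (0.08 log units; within the scatter) and the propyl change gives a 1.1-fold lower number from compound 2 to compound 4 (0.04 log units; within the scatter), whereas the butyl change on the shortest chain gives a 7.9-fold lower number from compound 1 to compound 4 (0.90 log units; beyond the scatter). The methyl change therefore does not carry over unchanged from the shorter chain to the longer one, and its step depends on the chain on which it is made: the same change on two cores in this assay, a 7.3-fold lower number (0.86 log units; beyond the scatter) from compound 1 to compound 2 and a 1.2-fold higher number (0.08 log units; within the scatter) from compound 3 to compound 4, 8.9-fold (0.95 log units) apart, beyond the scatter of two such steps The propyl change does not carry over either, and these comparisons show neither why the step fades nor any reversal of direction past compound 3, only that compound 2, compound 3 and compound 4 cannot be told apart in this assay: the same change on two cores in this assay, a 9.6-fold lower number (0.98 log units; beyond the scatter) from compound 1 to compound 3 and a 1.1-fold lower number (0.04 log units; within the scatter) from compound 2 to compound 4, 8.9-fold (0.95 log units) apart, beyond the scatter of two such steps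

The compounds shown leave open whether a still longer chain would stay level with compound 3 and compound 4 or would depart from them, and at what length that might occur. They also leave open whether a branched chain, or a chain ending in an amine or a carboxylic acid, would follow the same course on the shared core.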